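A few compounds are considered here, and "the series" means these few. Any claim that something is new, unique, unknown or untested is made for them only; others in the source may bear on it.

Measured so far: compound 1 `COc1ccc2c(c1)NC(=O)CN2c1nc(Nc2ccc(C#N)cc2)nc2ccccc12` gives 8.31 nM in a functional assay on MDA-MB-231 cells (Homo sapiens) for inhibition, read by sulforhodamine B assay, with a stated time of 48 h; a higher number here means a weaker inhibitor of growth, a lower number a stronger inhibitor of growth; compound 2 `COc1ccc2c(c1)NC(=O)CN2c1nc(COCCCC(=O)NO)nc2ccccc12` gives 1020 nM in the same assay.

Compound 2 stands at the highest of the two numbers, with compound 1 at a 120-fold higher number from compound 1 to compound 2 (2.09 log units; beyond the scatter) when read in the reverse direction. Compound 3 `CCOc1nc(N2CC(=O)Nc3cc(OC)ccc32)c2ccccc2n1` has not yet been measured. The change from compound 2 to it is ethoxy in place of (3-(hydroxycarbamoyl)propoxy)methyl on an aromatic carbon. Going by the values given here, the one measured step that bears on this position is a 120-fold higher number from compound 1 to compound 2 (2.09 log units; beyond the scatter), a large step for a substitution at the same aromatic carbon. That step shows the position is sensitive, but the entering ethoxy group resembles neither of the two groups measured there, so the direction is uncertain. The expectation is a modest step of a 2.0-fold higher number from compound 2 to compound 3 (0.29 log units; within the scatter), toward a somewhat weaker inhibitor of growth. Compound 3 is therefore estimated at 2000 nM, with a range of 400 nM to 10000 nM.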

Compound 3, concentration for 50% growth inhibition: 15.4 nM
The estimate for compound 3 lay 130-fold (2.11 log units) above the measured number; measured number below the stated range.
By their numbers in this assay, from the lowest: compounds 1 and 3 (each within the scatter of the next); then compound 2.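

In this assay the step of a 66-fold lower number from compound 2 to compound 3 (1.82 log units; beyond the scatter) shows that this aromatic carbon, between two ring nitrogen atoms, does not reject every replacement for (4-cyanophenyl)amino: the large rise seen with (3-(hydroxycarbamoyl)propoxy)methyl does not return with ethoxy. The step of a 1.9-fold higher number from compound 1 to compound 3 (0.27 log units; within the scatter) lies within the scatter, so ethoxy and (4-cyanophenyl)amino cannot be told apart here, and a ring in this group is not needed for a number of this size. No measurement is at hand that explains why the (3-(hydroxycarbamoyl)propoxy)methyl group stands apart from the other two.

As far as these compounds go, it remains open whether the high number of compound 2 comes from the length of its chain or from its hydroxycarbamoyl end. A longer alkoxy chain without that end, a chain ending in a carboxylic acid, or a simple amine at this carbon would help separate these possibilities.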